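The compounds below may be only part of what the source reports. "The series", "measured", "known", "first", "only" and "open" are said of these compounds alone.

Measured in a functional assay on A549 cells (Homo sapiens) for inhibition, read by MTT assay, with a stated time of 72 h; on this read-out higher numbers stand for weaker inhibition and lower numbers for stronger inhibition:

Compound 1, `COc1cc(N(C)CCN(C)C)c(NC(=O)C=C(C)C)cc1Nc1nc2c(c(-c3cn(C)c4ccccc34)n1)CSCC2`, gives 583 nM.
Compound 2, `C/C=C\C(=O)Nc1cc(Nc2nc3c(c(-c4cn(C)c5ccccc45)n2)CSCC3)c(OC)cc1N(C)CCN(C)C`, gives 6860 nM.
Compound 3, `COc1cc(N(C)CCN(C)C)c(NC(=O)C=C(C)C)cc1Nc1nc2c(c(-c3cn(C)c4ccccc34)n1)CS(=O)(=O)CC2`, gives 787 nM.

Compound 1 and compound 2 differ by one change, (prop-1-en-1-yl in place of 2-methylprop-1-en-1-yl on a carbonyl carbon), and that change produced a 12-fold higher number from compound 1 to compound 2 (1.07 log units; beyond the scatter). Compound 3 carries the same amide as compound 1 but on a different core; the difference between the two cores is not broken down here, and their two values lie close to each other. Within the data shown here, compound 4, `C/C=C\C(=O)Nc1cc(Nc2nc3c(c(-c4cn(C)c5ccccc45)n2)CS(=O)(=O)CC3)c(OC)cc1N(C)CCN(C)C`, has not yet been measured in this assay; it differs from compound 3 by prop-1-en-1-yl in place of 2-methylprop-1-en-1-yl on a carbonyl carbon, the same change as the one between compound 1 and compound 2. The step from compound 3 to compound 4 is expected to be a 12-fold higher number from compound 3 to compound 4 (1.07 log units; beyond the scatter), a step of similar size to the earlier one, because the pair compound 1 and compound 2 showed a 12-fold higher number from compound 1 to compound 2 (1.07 log units; beyond the scatter). Compound 4 is therefore estimated at 9300 nM in this assay, most likely between 3500 nM and 25000 nM.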

Compound 4, half-maximal inhibitory concentration: 4260 nM
For compound 4 the middle estimate is 2.2-fold (0.34 log units) above the measured one; the range from low to high includes it.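

In this assay replacing 2-methylprop-1-en-1-yl with prop-1-en-1-yl on the carbonyl carbon gives a 5.4-fold higher number from compound 3 to compound 4 (0.73 log units; beyond the scatter) so the weakening seen on the core of compound 1 also appears on the core of compound 3. The two steps run the same way and their sizes cannot be told apart: the same change on two cores in this assay, a 12-fold higher number (1.07 log units; beyond the scatter) from compound 1 to compound 2 and a 5.4-fold higher number (0.73 log units; beyond the scatter) from compound 3 to compound 4, 2.2-fold (0.34 log units) apart, within the scatter of two such steps. This supports carrying the change between these two cores in this cell assay, but it does not show why the change acts as it does or that it would hold on any other core.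

The compounds shown leave open how other groups on this carbonyl carbon would behave, such as a plain vinyl group or a longer chain. They also leave open whether an amine other than the one shared here would alter the step.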